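This account rests on a few compounds, and the source may have more. Where it says the series, first, only, none or still open, it means among the compounds named here.

Measured in a functional assay on MDBK cells (Bos taurus) for cytotoxicity; a lower number here means that less compound is tolerated, a higher number that more compound is tolerated:
- compound 1 `CO/N=C(\C#N)C(=O)NCC1=NOC(C(C)(C)C)C1`: > 100 ug/mL (a limit)
- compound 2 `C=CCO/N=C(\C#N)C(=O)NCC1=NOC(c2ccccc2)(c2ccccc2)C1`: 100 ug/mL
- compound 3 `CO/N=C(/C#N)C(=O)NCC1=NOC(C(C)(C)C)C1`: > 100 ug/mL (a limit)

Compound 1 stands at > 100 ug/mL, which is a limit of this assay and not a number. Compound 3 reports > 100 ug/mL, which is also a limit. Within the data shown here, compound 2 gives 100 ug/mL, the only actual number so far.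

The next compound is compound 4 `CC(C)O/N=C(\C#N)C(=O)NCC1=NOC(C(C)(C)C)C1`, which keeps the core of compound 1 and changes one group: isopropyl in place of methyl on an oxygen. Among the measured compounds shown here, the one measured step is a step that the two limits leave unreadable from compound 1 to compound 3. It concerns (the fact that one of compounds 1 and 3 is drawn with a defined configuration and the other without, at the place where they differ), not the group changing here, so it offers no size to carry over. The expectation therefore rests on (the limit of > 100 ug/mL in this assay, at which 2 of the 3 values shown sit), which compound 1 shares with compound 3. The expected change is a number no higher from compound 1 to compound 4 (the limit leaves the size open), so no shift beyond the usual scatter is anticipated, and a further limit is the likeliest report. For compound 4 the estimate is 100 ug/mL, with an expected range of 50 ug/mL to 200 ug/mL.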

Compound 4, half-maximal cytotoxic concentration: > 100 ug/mL
Compound 4 gave a limit, no number; the forecaster's own chance of this, stated with the estimate: 75%; the middle value lies on the limit itself.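

Among these compounds, compound 1 and compound 4 each report a limit and not a number, so no step between them can be read. The compounds shown leave open whether isopropyl in place of methyl on an oxygen changes the concentration tolerated at all.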